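A few compounds are considered here, and "the series" means these few. Any claim that something is new, unique, unknown or untested is made for them only; others in the source may bear on it.

Of the compounds shown here, two of a shared core have been tested so far. Compound 1 `O=C(O)[C@@H]1CCCN1C(=O)CN(c1nc(Cl)nc2[nH]cnc12)C1CC1` gives 31.5% in a functional assay on the whole organism (Tail, strain ICR) with Mus musculus as the target, in the tail flick test, with a stated time of 30 min, at a dose of 25 umol/kg by the oral route (a lower number here means a weaker effect, a higher number a stronger effect of the compound at the dose given), and compound 2 `CSCC[C@H](NC(=O)CN(c1nc(Cl)nc2[nH]cnc12)C1CC1)C(=O)OCc1ccccc1` gives 22.2% in this assay. The two numbers lie within the usual scatter of one another, so compound 2 does not stand apart from compound 1 on what has been measured; the small gap between them tells nothing about a trend. Compound 3 `NC(=O)CC[C@H](NC(=O)CN(c1nc(Cl)nc2[nH]cnc12)C1CC1)C(=O)OCc1ccccc1` is the next compound to be measured in this assay. It differs from compound 2 in one place: carbamoyl in place of methylsulfanyl on a saturated chain carbon, three bonds along the chain from an amide-type nitrogen and a carbonyl carbon. Among the measured compounds shown here, no pair of measured compounds shows the effect of such a change, so there is no step to lean on. The expected step from compound 2 to compound 3 is therefore small, with no clear direction, a number 2.8 percentage points higher from compound 2 to compound 3 (within the scatter), which means little more than the scatter. On that basis compound 3 is estimated to give 25% in this assay, somewhere between 8% and 45%.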

Compound 3, a percentage reported as activity, at one dose (the size of the read-out at that dose, not a potency): 30.8%
Estimate against measurement, compound 3: 5.8 percentage points below, within the range that was stated.
By their numbers in this assay, from the lowest: compounds 2, 3 and 1 (each within the scatter of the next).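

In this assay, carbamoyl in place of methylsulfanyl on this saturated chain carbon gives a number 8.6 percentage points higher from compound 2 to compound 3 (within the scatter), the first step measured at this position. At this dose, the read-out cannot tell the two groups apart, even though carbamoyl adds a hydrogen-bond donor that methylsulfanyl lacks. Nothing available explains this result or shows why the two compounds read alike.

Still open, as far as these compounds go, is whether another group at this position, such as an amine, a carboxylic acid or a longer chain, would produce a step beyond the scatter. A single dose and time point also leave open whether compound 2 and compound 3 would separate under other conditions.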